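A few compounds are considered here, and "the series" means these few. Any claim that something is new, unique, unknown or untested is made for them only; others in the source may bear on it.

Measured so far in a functional assay for inhibition, with Homo sapiens as the target; on this read-out lower numbers stand for stronger inhibition and higher numbers for weaker inhibition:

Compound 1 `COc1ccc(Nc2nccc(-c3cccnc3)n2)cc1` gives 1700 nM
Compound 2 `CNc1ccc(Nc2nccc(-c3ccccn3)n2)cc1` gives 1400 nM

Going by the values given here, only these two compounds have numbers so far. Compound 2, at 1400 nM, lies within the usual scatter of compound 1, at 1700 nM, so the two values cannot be told apart in this assay. The next compound to be considered is compound 3 `CNc1ccc(Nc2nccc(-c3cccnc3)n2)cc1`. It has the same atoms as compound 2 joined differently, with pyridin-3-yl in place of pyridin-2-yl on an aromatic carbon, next to the ring nitrogen (pyridin-3-yl in place of pyridin-2-yl on an aromatic carbon). Among the compounds with values here, no measured step isolates this change, so its effect has no direct precedent in the data. Pyridin-3-yl is, however, also found in compound 1, whose value of 1700 nM offers the only indirect guide. No change beyond the scatter is therefore expected, and the estimated step of a 1.1-fold lower number from compound 2 to compound 3 (0.03 log units; within the scatter) is small, with no firm direction. For compound 3 the expected value is 1300 nM, with an estimated range from 450 nM to 3800 nM.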

Compound 3, half-maximal inhibitory concentration: 2100 nM
Beside the measured number, compound 3's estimate is 1.6-fold (0.21 log units) below it; measured number inside the range.
By their numbers in this assay, from the lowest: compounds 2, 1 and 3 (each within the scatter of the next).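

In this assay, going by these compounds alone, pyridin-3-yl in place of pyridin-2-yl on an aromatic carbon next to the ring nitrogen gives a 1.5-fold higher number from compound 2 to compound 3 (0.18 log units; within the scatter) and is the first direct reading at this position: which of these two pyridinyl groups sits there makes no difference that this assay can resolve. Compound 3 also opens a second comparison, since methylamino in place of methoxy on an aromatic carbon gives a 1.2-fold higher number from compound 1 to compound 3 (0.09 log units; within the scatter) and likewise leaves the two compounds indistinguishable, so neither single change separates the numbers. No supporting measurement is available that could explain either result.

All three compounds lie within the scatter of one another, so the data leave open whether any change at either place can move the number beyond it. Going by these compounds, it also remains open whether pyridin-4-yl or a plain phenyl at the position next to the ring nitrogen, or dimethylamino or a longer alkoxy chain in place of methylamino, would give a number that can be told apart from these.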